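This account rests on a few compounds, and the source may have more. Where it says the series, first, only, none or still open, it means among the compounds named here.

Three compounds built on one shared core have so far been run in an ADME assay on microsomes from liver (Rattus norvegicus) for metabolic stability, read by LC-MS, tested at 0.5 uM; a lower number here means that the compound disappears faster, a higher number that the compound lasts longer. Compound 1 `COc1ccc(CCOc2ccc(-c3c(C)nc(C)c([C@H](OC(C)(C)C)C(=O)O)c3N3CCC(C)(C)CC3)cc2)cc1` gives > 2 h, which is a limit of the assay rather than a number. Compound 2 `COc1cccc(CCOc2ccc(-c3c(C)nc(C)c([C@H](OC(C)(C)C)C(=O)O)c3N3CCC(C)(C)CC3)cc2)c1` gives > 2 h, again a limit rather than a number. Compound 3 `Cc1nc(C)c([C@H](OC(C)(C)C)C(=O)O)c(N2CCC(C)(C)CC2)c1-c1ccc(SCCc2ccc(F)cc2)cc1` gives > 2 h, also a limit rather than a number. Compound 3 thus stands exactly where every value shown stands, as summed up by the limit of > 2 h in this assay, at which 3 of the 3 values shown sit. The change now followed leads to compound 4 `Cc1ccc(CCOc2ccc(-c3c(C)nc(C)c([C@H](OC(C)(C)C)C(=O)O)c3N3CCC(C)(C)CC3)cc2)s1`: 2-(5-methylthiophen-2-yl)ethoxy in place of (2-(4-fluorophenyl)ethyl)sulfanyl on an aromatic carbon. Three measured steps resemble it, each a swap within the side chain: a step that the two limits leave unreadable from compound 1 to compound 2, a step that the two limits leave unreadable from compound 1 to compound 3 and a step that the two limits leave unreadable from compound 2 to compound 3; because all of them begin and end at the limit described by the limit of > 2 h in this assay, at which 3 of the 3 values shown sit, none of their sizes can be read, so no direction can be drawn from them. On that basis compound 4 is expected to reach the same limit, an expected step that the limit leaves unreadable from compound 3 to compound 4. For compound 4 in this assay the estimate is 2.5 h, within a range from 1 h to 5 h.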

Compound 4, half-life: > 2 h
Compound 4: no number, only a limit (the forecaster's own chance of this, stated with the estimate: 70%); the middle value is on the limit's open side.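

In this assay compound 4 gives > 2 h as a limit, not a number. Going by these compounds alone, no step from compound 1, compound 2 or compound 3 to compound 4 can be read, since all four sit at the same limit: the limit of > 2 h in this assay, at which 4 of the 4 values shown sit.

How long each of these compounds actually lasts, and whether the side-chain swaps change it at all, stays open.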